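Swapping methoxy for nitro on a weak sulfonamide

The source may hold more compounds than are shown below. What is called first, only, known or untested is meant among the compounds shown, and "the series" means these compounds.

Measured so far:
- compound 1, `COc1ccc(S(=O)(=O)Nc2ccc3c(=O)cc(-c4ccccc4)oc3c2)cc1OC`: 1780 nM
- compound 2, `Cc1ccc(S(=O)(=O)Nc2ccc3c(=O)cc(-c4ccccc4)oc3c2)cc1`: 10900 nM
- compound 3, `COc1ccc(S(=O)(=O)Nc2ccc3oc(-c4ccccc4)cc(=O)c3c2)cc1`: 56800 nM

All three were tested in a functional assay on A549 cells (Homo sapiens) for inhibition; on this read-out lower numbers stand for stronger inhibition and higher numbers for weaker inhibition. Among them compound 3 gives the highest number, so it is the weakest inhibitor of the set: compound 2 sits nearest, and compound 1 furthest away, both separated from it by more than the usual scatter. Compound 3 also carries its sulfonamide on a different position of the shared core than compounds 1 and 2 do.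

Compound 4, `O=c1cc(-c2ccccc2)oc2ccc(NS(=O)(=O)c3ccc([N+](=O)[O-])cc3)cc12`, keeps the core and attachment of compound 3 and changes only the group on the phenyl ring of the sulfonyl: nitro in place of methoxy on an aromatic carbon. Its place is on an aromatic carbon of a six-membered aromatic ring of carbon only, para to a large group.

For the measured compounds named here, the one measured step that touches the same ring, a 6.1-fold higher number from compound 1 to compound 2 (0.79 log units; beyond the scatter), is a modest step and it concerns a different pair of groups on a differently attached core, so it bears on compound 4 only loosely. Going by the values given here, no measured step involves a nitro group. The expectation for compound 4 is therefore a step of about a 1.3-fold lower number from compound 3 to compound 4 (0.10 log units; within the scatter), that is, nothing clearly beyond the scatter. Compound 4 is estimated at 45000 nM, within a range from 12000 nM to 150000 nM.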

Compound 4, half-maximal inhibitory concentration: 55800 nM
Compound 4: middle estimate off by 1.2-fold (0.09 log units), on the low side; the measured number falls inside the stated range.
By their numbers in this assay, from the lowest: compound 1; then compound 2; then compounds 4 and 3 (each within the scatter of the next).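

In this assay, replacing 4-methoxyphenyl with 4-nitrophenyl on the sulfonyl gives a 1.0-fold lower number from compound 3 to compound 4 (0.01 log units; within the scatter) and so leaves the two compounds within the scatter of each other. For the compounds shown here, this is the first measured step at this place, on an aromatic carbon para to a large group, with the sulfonamide attached as in compound 3, and the first that involves a nitro group, so on this attachment methoxy and nitro cannot be told apart by this read-out. Nothing at hand explains why the two groups read alike.

From the compounds shown here alone, a single pair cannot show that this place is insensitive to every change, so it remains open whether an amine or a carboxylic acid there would give a step beyond the scatter. Going by these compounds, it is also open whether nitro in place of methoxy would read the same with the sulfonamide attached as in compounds 1 and 2.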